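Dropping One Chloro From an Aryl Amide

This account rests on a few compounds, and the source may have more. Where it says the series, first, only, none or still open, it means among the compounds named here.

Compound 1 `O=C(/C=C/C(=O)N1C/C(=C\c2ccccc2)C(=O)/C(=C/c2ccccc2)C1)Nc1ccc(Cl)c(Cl)c1` gives the higher of two measured numbers in a functional assay on L1210 cells (Mus musculus) for cytotoxicity (a lower number here means a stronger inhibitor, a higher number a weaker inhibitor), with 7500 nM. Compound 2 `O=C(/C=C/C(=O)N1C/C(=C\c2ccc([N+](=O)[O-])cc2)C(=O)/C(=C/c2ccc([N+](=O)[O-])cc2)C1)Nc1ccc([N+](=O)[O-])cc1` gives the lower value, 1000 nM, a gap beyond the usual scatter. Compound 3 `O=C(/C=C/C(=O)N1C/C(=C\c2ccccc2)C(=O)/C(=C/c2ccccc2)C1)Nc1ccc(Cl)cc1` differs from compound 1 only by hydrogen in place of chloro on an aromatic carbon. For the measured compounds named here, no measured pair isolates this change, so the step is expected to be small, within or barely beyond the scatter, and if anything toward a weaker compound. Compound 3 is therefore estimated at 10000 nM, ranging from 3000 nM to 30000 nM, which corresponds to an expected step of a 1.3-fold higher number from compound 1 to compound 3 (0.12 log units; within the scatter).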

Compound 3, half-maximal inhibitory concentration: 7800 nM
Compound 3: the middle estimate sits 1.3-fold (0.11 log units) above what was measured; the measured number falls inside the stated range.
By their numbers in this assay, from the lowest: compound 2; then compounds 1 and 3 (each within the scatter of the next).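

Replacing the chloro group that sits ortho to a chloro group with hydrogen, which turns 3,4-dichlorophenyl into 4-chlorophenyl, gives a 1.0-fold higher number from compound 1 to compound 3 (0.02 log units; within the scatter) in this assay. At this ring position, chloro and hydrogen therefore cannot be told apart in this read-out, something compound 1 and compound 2 could not show because they differ in several places. No measurement shown explains this result.

On these data alone, it remains open whether an amine, a methoxy group or a carboxylic acid at this position would change the number. As far as these compounds go, the effect of replacing the remaining chloro group also remains open.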